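A few compounds are considered here, and "the series" means these few. Any claim that something is new, unique, unknown or untested is made for them only; others in the source may bear on it.

Measured compounds in an ADME assay on HEL cells (Homo sapiens) for cytotoxicity, with a stated time of 3 days; on this read-out lower numbers stand for higher toxicity in this test and higher numbers for lower toxicity in this test:
Compound 1 `Cc1cc(N2CCCC2)c2ncc(CSCCc3ccccc3)n2c1` gives > 100 ug/mL, a limit of the test rather than a number.
Compound 2 `Cc1cc(N2CCCC2)c2ncc(CSCc3ccccc3)n2c1` gives >= 20 ug/mL, likewise a limit.
Compound 3 `Cc1cc(N2CCCC2=O)c2ncc(CSCCc3ccccc3)n2c1` gives 20 ug/mL.

Compound 2 therefore stands at a limit (the limit of >= 20 ug/mL in this assay, at which 1 of the 3 values shown sits), and two of the three values shown are limits. Compound 1 sits at the other limit (the limit of > 100 ug/mL in this assay, at which 1 of the 3 values shown sits). Compound 4 `Cc1cc(-n2cccc2)c2ncc(CSCc3ccccc3)n2c1` differs from compound 2 in one place: 1H-pyrrol-1-yl in place of pyrrolidin-1-yl on an aromatic carbon. Neither measured step covers this change. The step that the two limits leave unreadable from compound 1 to compound 2 concerns the chain bound to the sulfur, and the step of an at least 5.0-fold lower number from compound 1 to compound 3 (0.69 log units; beyond the scatter) concerns a carbonyl added to the pyrrolidine ring, not its replacement by an aromatic ring. The account thus has no direct guide for compound 4, and the expectation is a step of a number no higher from compound 2 to compound 4 (the limit leaves the size open) of no clear direction, within the scatter. Compound 4 is estimated at 20 ug/mL in this assay, between 5 ug/mL and 100 ug/mL, with a real chance that only a limit is reported.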

Compound 4, minimum cytotoxic concentration: 100 ug/mL
For compound 4 the middle estimate is 5.0-fold (0.70 log units) below the measured one; low and high end bracket the measured number.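

No step can be read from compound 2 to compound 4, because compound 2 is known only as a limit: the limit of >= 20 ug/mL in this assay, at which 1 of the 4 values shown sits.

The compounds shown leave open whether, and how far, 1H-pyrrol-1-yl in place of pyrrolidin-1-yl shifts the read-out in this assay.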